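Meta substituent series on the arylsulfone: methyl to hydrogen

The source may report more compounds than this note shows. Statements on the series, on what has been measured and on what is new or still open speak of the compounds shown alone.

Compound 1 `CN1CCC(c2n[nH]c3ccc(S(=O)(=O)c4cccc(Cl)c4)cc23)CC1` gives in an assay on HeLa cells for displacement of a labelled ligand from 5-hydroxytryptamine receptor 6 (Homo sapiens) (on this read-out higher numbers stand for weaker inhibition and lower numbers for stronger inhibition), a value of 19 nM. Within the data shown here, compound 2 `Cc1cccc(S(=O)(=O)c2ccc3[nH]nc(C4CCN(C)CC4)c3c2)c1` gives in this assay 50 nM, and the change a 2.6-fold higher number from compound 1 to compound 2 (0.42 log units; beyond the scatter) places compound 2 at the higher of the two numbers so far. Compound 3 `CN1CCC(c2n[nH]c3ccc(S(=O)(=O)c4ccccc4)cc23)CC1` is to be measured; the change is hydrogen in place of methyl on an aromatic carbon. Among the measured compounds shown here, only the step from compound 1 to compound 2 bears on it, and it concerns a different exchange at the same carbon, so its size serves only as a rough bound. A step of a 1.3-fold lower number from compound 2 to compound 3 (0.12 log units; within the scatter) is expected, toward a somewhat lower number. Compound 3 is estimated at 38 nM, within 14 nM to 105 nM.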

Compound 3, inhibition constant: 55 nM
For compound 3 the middle estimate is 1.4-fold (0.16 log units) below the measured one; measured number inside the range.
By their numbers in this assay, from the lowest: compound 1; then compounds 2 and 3 (each within the scatter of the next).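

In this assay, the change from 3-methylphenyl to phenyl gives a 1.1-fold higher number from compound 2 to compound 3 (0.04 log units; within the scatter), so this carbon does not distinguish methyl from hydrogen. Among the three groups shown, only chloro stands apart: hydrogen in place of chloro gives a 2.9-fold higher number from compound 1 to compound 3 (0.46 log units; beyond the scatter), a step of similar size to that for methyl in place of chloro. No measurement available here accounts for the position of chloro.

Going by these compounds, whether the lower number is specific to chloro remains open. Fluoro, bromo, methoxy, trifluoromethyl or an amine on this carbon would test that.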